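A few compounds are considered here, and "the series" means these few. Any claim that something is new, unique, unknown or untested is made for them only; others in the source may bear on it.

Of the compounds shown here, three built on one shared core have been tested in a functional assay on MCF7 cells (Homo sapiens) for antiproliferative activity, read by MTT assay, with a stated time of 48 h; a higher number here means a weaker inhibitor, a lower number a stronger inhibitor. Compound 1 `N#CC1=C(N)Oc2c(c3nc4ccccc4nc3c3ccccc23)C12C(=O)N(Cc1cnnn1-c1ccc(F)cc1)c1ccccc12` bears a 4-fluorophenyl on an aromatic nitrogen of the five-membered aromatic ring with 3 nitrogen. In this assay compound 1 sits at a limit of the assay, > 50000 nM. Going by the values given here, compound 2 `N#CC1=C(N)Oc2c(c3nc4ccccc4nc3c3ccccc23)C12C(=O)N(Cc1cnnn1-c1cccc(Cl)c1)c1ccccc12` has 3-chlorophenyl in place of 4-fluorophenyl on an aromatic nitrogen, and in this assay compound 2 gives 43600 nM, the one genuine number in the set; the move is an at least 1.1-fold lower number from compound 1 to compound 2 (0.05 log units; that floor lies within the scatter). Compound 3 `N#CC1=C(N)Oc2c(c3nc4ccccc4nc3c3ccccc23)C12C(=O)N(Cc1cnnn1-c1ccc(S(N)(=O)=O)cc1)c1ccccc12` carries 4-sulfamoylphenyl on that aromatic nitrogen. In this assay compound 3 stands at a limit of the assay, > 50000 nM. The move from compound 2 is an at least 1.1-fold higher number from compound 2 to compound 3 (0.05 log units; that floor lies within the scatter), and the move from compound 1 is a step that the two limits leave unreadable from compound 1 to compound 3, since (the limit of > 50000 nM in this assay, at which 2 of the 3 values shown sit).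

Compound 4 `Cc1ccc(C)c(-n2nncc2CN2C(=O)C3(C(C#N)=C(N)Oc4c3c3nc5ccccc5nc3c3ccccc43)c3ccccc32)c1` differs from compound 3 by 2,5-dimethylphenyl in place of 4-sulfamoylphenyl on an aromatic nitrogen. Among the compounds with values here, the only readable steps, an at least 1.1-fold lower number from compound 1 to compound 2 (0.05 log units; that floor lies within the scatter) and an at least 1.1-fold higher number from compound 2 to compound 3 (0.05 log units; that floor lies within the scatter), are each at a floor within the scatter, so nothing here argues for a shift beyond the scatter in this assay. Compound 4 is therefore expected to give about 50000 nM, within 20000 nM to 150000 nM, a step of a number no higher from compound 3 to compound 4 (the limit leaves the size open) that is expected to stay within the scatter.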

Compound 4, half-maximal inhibitory concentration: > 50000 nM
Compound 4 ended at the assay's limit; the forecaster's own chance of this, stated with the estimate: 60%; the middle value lies on the limit itself.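

Going by these compounds alone, on the aromatic nitrogen of the five-membered aromatic ring with 3 nitrogen, the earlier compounds carried a halogen-bearing phenyl or the 4-sulfamoylphenyl, whereas 2,5-dimethylphenyl is a phenyl with carbon-only substituents, 0 hydrogen-bond donors and 0 hydrogen-bond acceptors, and in this assay it too leaves the compound at the limit of the assay. Within the data shown here, the one readable step is an at least 1.1-fold higher number from compound 2 to compound 4 (0.05 log units; that floor lies within the scatter), so this change gives no sign of a shift beyond the scatter, and compound 2 remains the only compound in the set with a genuine number. The steps to compound 4 from compound 1 and from compound 3 cannot be read, because the values of those compounds are limits and not numbers: the limit of > 50000 nM in this assay, at which 3 of the 4 values shown sit.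

Going by these compounds, how far compound 1, compound 3 and compound 4 actually lie past that limit stays open, and so does any ranking among them. Also open, on these data alone, is whether a carboxylic acid or an amine on the phenyl, or a longer chain in place of the phenyl, would bring a value clearly inside the range of the assay.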